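The source may hold more compounds than are shown below. What is called first, only, known or untested is meant among the compounds shown, and "the series" means these compounds.

Measured so far:
Compound 1 `CCC(C)C(NC(=O)n1nnc2ccccc21)C(=O)NC1CCCCC1`: 40200 nM
Compound 2 `CC(C)C(NC(=O)n1nnc2ccccc21)C(=O)NC1CCCC1`: a limit only, > 100000 nM

In a functional assay on MIA PaCa-2 cells (Homo sapiens) for inhibition (a higher number here means a weaker inhibitor, a lower number a stronger inhibitor), compound 1 gives 40200 nM, which marks it as a weak inhibitor with a measurable number. For compound 2 the assay reports no number but only a limit, > 100000 nM. From the compounds shown here alone, compound 2 therefore stands at the ceiling of what the measurement can show, namely (the limit of > 100000 nM in this assay, at which 1 of the 2 values shown sits); how far beyond it the true value lies is unknown.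

Compound 3 `CC(C)C(NC(=O)n1nnc2ccccc21)C(=O)NC1CCCCC1` is the compound still to be measured. It differs from compound 2 by cyclohexyl in place of cyclopentyl on an amide-type nitrogen. Compound 1 carries the same cyclohexyl group on that nitrogen and gives a number rather than a limit, so a step toward stronger inhibition is plausible from compound 2 to compound 3, of modest size; with compound 2 known only as a limit, its exact size is open.

Compound 3 is expected to give about 80000 nM, in the range 30000 nM to 250000 nM. The expected step from compound 2 to compound 3 is an at least 1.2-fold lower number from compound 2 to compound 3 (0.09 log units; that floor lies within the scatter).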

Compound 3, half-maximal inhibitory concentration: > 100000 nM
Compound 3: a limit, no number; the forecaster's own chance of this, stated with the estimate: 40%; middle value at least 1.2-fold (0.09 log units) away from the limit.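

In this assay, cyclohexyl in place of cyclopentyl on an amide-type nitrogen does not by itself bring a number into reach, since compound 3, like compound 2, gives only a limit: the limit of > 100000 nM in this assay, at which 2 of the 3 values shown sit.

The step between these two limits cannot be read. Within the data shown here, what the earlier compounds could not show is that the side chain also counts: hydrogen in place of methyl on a saturated chain carbon, three bonds along the chain from an amide-type nitrogen and a carbonyl carbon, gives an at least 2.4-fold higher number from compound 1 to compound 3 (0.39 log units; beyond the scatter).

From the compounds shown here alone, how far compound 2 and compound 3 lie past their limits stays open, so any effect of ring size remains unknown. Also open, going by these compounds, is whether a longer chain at that carbon, or an amine on the cyclohexyl, would give stronger inhibition than compound 1 at 40200 nM.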